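Chain extension at the ethyl group of the shared core

The compounds below may be only part of what the source reports. "The series", "measured", "known", "first", "only" and "open" are said of these compounds alone.

compound 1 `CCc1nnc2c(Cl)c(N3CCC(c4ccccc4)CC3)ccn12`: 386 nM
compound 2 `CCc1nnc2c(C(F)(F)F)c(N3CCC(c4ccccc4)CC3)ccn12`: 116 nM

In a functional assay on CHO cells for positive allosteric modulation of metabotropic glutamate receptor 2 (Homo sapiens), read by GTPgammaS binding, with a stated time of 30 min (on this read-out lower numbers stand for an effect already at smaller amounts and higher numbers for an effect only at larger amounts of compound), compound 1 gives 386 nM and compound 2 gives 116 nM. Among the compounds with values here, compound 2 carries the lowest of the two numbers; the only measured step is a 3.3-fold lower number from compound 1 to compound 2 (0.52 log units; beyond the scatter), and it concerns a different position. Compound 3 `CCCCc1nnc2c(C(F)(F)F)c(N3CCC(c4ccccc4)CC3)ccn12` differs from compound 2 by ethyl in place of hydrogen on a saturated chain carbon, two bonds along the chain from an aromatic carbon. Within the data shown here, no measured step bears on a change of this kind, so no direction can be drawn from the numbers; the expectation is a step in this assay no larger than the scatter, estimated as a 1.0-fold higher number from compound 2 to compound 3 (0.01 log units; within the scatter). Compound 3 is therefore expected at 120 nM, with a range from 40 nM to 360 nM.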

Compound 3, half-maximal effective concentration: 24 nM
Estimate against measurement, compound 3: 5.0-fold (0.70 log units) above; the measured number lies below the stated range.
By their numbers in this assay, from the lowest: compound 3; then compound 2; then compound 1.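

Extending the chain from ethyl to butyl is not a neutral change on this core: in this assay it gives a 4.8-fold lower number from compound 2 to compound 3 (0.68 log units; beyond the scatter), so this position responds to chain length. Within the data shown here, the shared core therefore has a second site, apart from the one changed between compound 1 and compound 2, where a single change moves the number beyond the scatter. No measurement at hand accounts for this step.

As far as these compounds go, whether a longer chain such as hexyl moves the number further, or a cyclopropyl group serves as well as butyl, remains open. Also open, from the compounds shown here alone, is whether butyl gives a similar step on the chloro core of compound 1.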